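Changing the Aryl Group Attached to the Sulfur

A few compounds are considered here, and "the series" means these few. Any claim that something is new, unique, unknown or untested is made for them only; others in the source may bear on it.

Of the compounds shown here, three of a shared core have been measured. Compound 1 `Nc1cc(N)c2nc(-c3ccccc3)c(Oc3ccc(Cl)c(Cl)c3)nc2c1` gives 47900 nM in a functional assay on UACC-62 cells (Homo sapiens) for inhibition, read by sulforhodamine B assay, with a stated time of 48 h; a higher number here means a weaker inhibitor of growth, a lower number a stronger inhibitor of growth. Compound 2 `Nc1cc(N)c2nc(-c3ccccc3)c(NCc3ccc(Cl)c(Cl)c3)nc2c1` gives 30900 nM in that assay, and compound 3 `Nc1cc(N)c2nc(-c3ccccc3)c(Sc3ccc(F)cc3)nc2c1` gives 31600 nM. Among these three numbers compound 3 stands second highest, though its separation from compound 2 and from compound 1 is within the scatter on both sides, so no order among the three can be claimed. For the measured compounds named here, the one single-point comparison available is a 1.5-fold lower number from compound 1 to compound 3 (0.18 log units; within the scatter), which moved (4-fluorophenyl)sulfanyl into the place of 3,4-dichlorophenoxy and produced no step beyond the scatter.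

Compound 4 `Nc1cc(N)c2nc(-c3ccccc3)c(Sc3ccc(Cl)c(Cl)c3)nc2c1` differs from compound 3 by 3,4-dichlorophenyl in place of 4-fluorophenyl on a sulfur. Going by the values given here, no measured pair isolates this exact exchange; the comparison from compound 1 to compound 3 alters the aryl group together with the atom that links it, and even that combined change stayed within the scatter. Compound 1 and compound 2 both carry the 3,4-dichloro pattern on their aryl groups and sit close to compound 3 in this assay, so there is no sign that this pattern moves the number far. Compound 4 is therefore expected to show a 1.1-fold higher number from compound 3 to compound 4 (0.04 log units; within the scatter), a step not beyond the scatter. The value of compound 4 in this assay is estimated at 35000 nM, with a range from 15000 nM to 80000 nM.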

Compound 4, concentration for total growth inhibition: 42700 nM
Compound 4: the middle estimate sits 1.2-fold (0.09 log units) below what was measured, within the range that was stated.
By their numbers in this assay, from the lowest: compounds 2, 3, 4 and 1 (each within the scatter of the next).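

Exchanging the aryl group on the sulfur with nothing else altered, 3,4-dichlorophenyl in place of 4-fluorophenyl, gives a 1.4-fold higher number from compound 3 to compound 4 (0.13 log units; within the scatter) in this assay, so this change alone produces no step beyond the scatter. Holding the 3,4-dichlorophenyl group fixed also separates the linking atom from the aryl group, which the earlier comparison had altered together: (3,4-dichlorophenyl)sulfanyl in place of 3,4-dichlorophenoxy gives a 1.1-fold lower number from compound 1 to compound 4 (0.05 log units; within the scatter), again within the scatter, so neither exchange taken singly moves the number measurably in these compounds. No measurement that could account for these numbers accompanies them.

The aryl groups shown on the sulfur carry only halogens, so it remains open whether a carboxylic acid or an amine on that aryl ring, or a longer alkyl chain on the sulfur in place of the ring, would give a step beyond the scatter. From the compounds shown here alone, the phenyl group and the two amino groups of the shared core are the same in all four compounds, so what an exchange at those places would do also remains open.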